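Carboxyphenyl placement and maximal response in a modulator series

The compounds below may be only part of what the source reports. "The series", "measured", "known", "first", "only" and "open" are said of these compounds alone.

Measured so far in an assay on HEK293 cells for positive allosteric modulation of metabotropic glutamate receptor 2 (Rattus norvegicus), read by thallium flux, with a stated time of 2.5 min; a higher number here means a larger maximal response, a lower number a smaller maximal response:
compound 1 `Cc1c(OCCCCOc2ccccc2C(=O)O)ccc(C(=O)CC(C)C)c1O`: 92.4%
compound 2 `Cc1c(OCCCCOc2cccc(C(=O)O)c2)ccc(C(=O)CC(C)C)c1C`: 12.1%
compound 3 `Cc1c(OCCCCOc2ccc(C(=O)O)cc2)ccc(C(=O)CC(C)C)c1C`: 19%

Compound 3 stands second of the three numbers in this assay; its nearest neighbour is compound 2, a gap within the scatter, while compound 1 lies far above it, beyond the scatter.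

Compound 4 `Cc1c(OCCCCOc2ccccc2C(=O)O)ccc(C(=O)CC(C)C)c1C` is compound 3 with 2-carboxyphenyl in place of 4-carboxyphenyl on an oxygen on a saturated carbon. For the measured compounds named here, the one measured step that bears on such a move of the carboxy group is a number 6.9 percentage points higher from compound 2 to compound 3 (within the scatter), which did not leave the scatter. Going by the values given here, compound 1 also carries 2-carboxyphenyl, but its core differs from that of compound 4, and no step between the two is available; its value only shows that a 2-carboxyphenyl compound in this set can reach a large response.

With one flat positional step and one high value on a different core, the expected direction for compound 4 is upward but uncertain; the step is estimated as a number 21 percentage points higher from compound 3 to compound 4 (beyond the scatter). Compound 4 is expected to give about 40% in this assay, within a wide range from 10% to 85%.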

Compound 4, largest response reached (reported as percent of maximum), in percent of the reference or control that the assay uses: 76.2%
Compound 4: the middle estimate sits 36.2 percentage points below what was measured; the range from low to high includes it.
By their numbers in this assay, from the lowest: compounds 2 and 3 (each within the scatter of the next); then compound 4; then compound 1.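

In this assay, 2-carboxyphenyl in place of 4-carboxyphenyl gives a number 57.2 percentage points higher from compound 3 to compound 4 (beyond the scatter), and 2-carboxyphenyl in place of 3-carboxyphenyl gives a number 64.1 percentage points higher from compound 2 to compound 4 (beyond the scatter); on the shared core, the 2-carboxyphenyl compound therefore stands clearly apart from the other two, whose own step, a number 6.9 percentage points higher from compound 2 to compound 3 (within the scatter), lies within the scatter. The large response seen with 2-carboxyphenyl is thus not confined to the core of compound 1, since methyl in place of hydroxy on the aromatic carbon gives only a number 16.2 percentage points lower from compound 1 to compound 4 (beyond the scatter), a modest step that still lies beyond the scatter. No measurement available here accounts for the separation of the 2-carboxyphenyl compound from the other two.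

Going by these compounds, it remains open whether a tetrazole or a primary amide in place of the carboxylic acid of 2-carboxyphenyl would keep a response of this size in this assay. Also open, on these data alone, is whether the same placement holds with a longer chain between the two oxygens, and whether the hydroxy-to-methyl step keeps its size and direction when the carboxy group stands elsewhere on the ring.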